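Chlorine-bearing core and the return to methylamino

This account rests on a few compounds, and the source may have more. Where it says the series, first, only, none or still open, it means among the compounds named here.

The measured compounds, with their values in an ADME assay on MT4 cells (Homo sapiens) for cytotoxicity, read by MTT assay, with a stated time of 4 days; a higher number here means that more compound is tolerated, a lower number that less compound is tolerated:
compound 1, `CNc1nc(Nc2ccc(C#N)cc2)nc(Oc2cccc3ccccc23)n1`, gives 30300 nM.
compound 2, `CCCNc1nc(Nc2ccc(C#N)cc2)nc(Oc2cccc3ccccc23)n1`, gives 29500 nM.
compound 3, `CCCNc1nc(Nc2ccc(C#N)cc2)nc(Oc2ccc3ccccc3c2Cl)n1`, gives only a limit of the assay, > 290000 nM.

Compound 1 and compound 2 share one core and differ only at the chain on the ring nitrogen. The step of a 1.0-fold higher number from compound 2 to compound 1 (0.01 log units; within the scatter) shows that hydrogen in place of ethyl on a saturated chain carbon bound to a nitrogen on an aromatic ring left the result essentially unchanged. Compound 3 carries a different core; how its core differs from that of compound 2 is not broken down here. For compound 3 the value is a limit and not a number, as the limit of > 290000 nM in this assay, at which 1 of the 3 values shown sits, records.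

Compound 4, `CNc1nc(Nc2ccc(C#N)cc2)nc(Oc2ccc3ccccc3c2Cl)n1`, is not yet measured. It stands to compound 3 exactly as compound 1 stands to compound 2: the same change, (hydrogen in place of ethyl on a saturated chain carbon bound to a nitrogen on an aromatic ring), made on the chlorine-bearing core. Since the earlier step of a 1.0-fold higher number from compound 2 to compound 1 (0.01 log units; within the scatter) fell within the scatter, compound 4 is expected to sit close to compound 3, so that the step that the limit leaves unreadable from compound 3 to compound 4 is estimated to be small. Because compound 3 reached only a limit > 290000 nM, compound 4 is also expected to reach the limit in this assay rather than a number. The estimate for compound 4 is 300000 nM, between 150000 nM and 600000 nM.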

Compound 4, half-maximal cytotoxic concentration: 171000 nM
Compound 4: the middle estimate sits 1.8-fold (0.24 log units) above what was measured, within the range that was stated.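

In this assay the change from propylamino to methylamino, carried over to the chlorine-bearing core, gives an at least 1.6-fold lower number from compound 3 to compound 4 (0.22 log units; that floor lies within the scatter) and so can be read only as a floor, not as a full size. For compound 3 the value > 290000 nM is a limit of the assay and not a number. The two cores therefore show no clear conflict, since the floor on the second core lies within the scatter just as the step on the first core does, but this does not show that the change carries over unaltered, and a real difference between the cores remains possible: the same change on two cores in this assay, a 1.0-fold higher number (0.01 log units; within the scatter) from compound 2 to compound 1 and an at least 1.6-fold lower number (0.22 log units; that floor lies within the scatter) from compound 3 to compound 4; the limit leaves it open whether they differ.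

The compounds shown leave open how a longer chain such as butyl, or a chain ending in an amine or a carboxylic acid, would read in this assay on either core, as the only chains here are propyl and methyl. They also leave open whether another halogen such as bromine in place of the chlorine would give a number or a limit, and whether any such result would hold for the methylamino and propylamino compounds alike.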